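A chloro group added to compound 3

This account rests on a few compounds, and the source may have more. Where it says the series, first, only, none or still open, it means among the compounds named here.

compound 1 (`O=C(O)CCCCC(CCSC(=O)c1ccccc1)SC(=O)c1ccccc1`): 0.68%
compound 2 (`O=C(CCCCC1CCSS1)Nc1ccccc1Cl`): "not active" (no number reported)
compound 3 (`O=C(CCCCC(CCSC(=O)c1ccccc1)SC(=O)c1ccccc1)Nc1ccccc1`): "not active" (no number reported)

In a functional assay on KB cells (Homo sapiens) for inhibition, read by MTT assay, with a stated time of 24 h, tested at 1 ug/mL (on this read-out higher numbers stand for more inhibition of growth at the one concentration tested and lower numbers for less inhibition of growth), compound 3 has no single number and is reported as "not active" (no number reported), the same entry as for compound 2. Only compound 1 carries a number. Compound 4 (`O=C(CCCCC(CCSC(=O)c1ccccc1)SC(=O)c1ccccc1)Nc1cccc(Cl)c1`) differs from compound 3 by one change, (chloro in place of hydrogen on an aromatic carbon), chloro in place of hydrogen on an aromatic carbon. Among the compounds with values here, no measured pair shows this change, so the data offer no step to read. No step beyond the scatter is expected in this assay, with growth inhibition expected to stay close to that of compound 1 (0.68%). For compound 4 the estimated value is 3%, with an expected range from 0% to 15%.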

Compound 4, percent growth inhibition at one concentration: 12.7%
For compound 4 the middle estimate is 9.7 percentage points below the measured one; low and high end bracket the measured number.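

Putting (3-chlorophenyl)amino in place of hydroxy on the carbonyl carbon gives, in this assay, a number 12 percentage points higher from compound 1 to compound 4 (beyond the scatter). Compound 3, which carries plain anilino there, is entered as not active without a number, so the step from phenyl to 3-chlorophenyl cannot be read as a size, although of these two only compound 4 has a number. Nothing at hand explains the result. On these data alone, whether fluoro, methoxy or an amine on the same ring would give a similar reading remains open.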